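The source may hold more compounds than are shown below. What is called first, only, known or untested is meant among the compounds shown, and "the series" means these compounds.

Compound 1 `O=C(Nn1c(CCC2CCCC2)nc2c(-c3ccc(Cl)cc3)n[nH]c2c1=O)c1ccccc1` gives 89.6%.
Compound 2 `Cc1cccc(C(=O)Nn2c(CC3CCCCC3)nc3c(-c4ccc(Cl)cc4)n[nH]c3c2=O)c1` gives 85.9%.
Compound 3 `CC(C)(C)c1ccc(C(=O)Nn2c(CC3CCCCC3)nc3c(-c4ccc(Cl)cc4)n[nH]c3c2=O)cc1` gives 65.2%.

These three numbers come from a functional assay on DU-145 cells (Homo sapiens) for cytotoxicity, read by sulforhodamine B assay, with a stated time of 2 days, tested at 100 uM; a lower number here means less inhibition, a higher number more inhibition at the concentration tested (going by the name of the read-out). Compound 3 holds the lowest number of the three: the single-group step a number 20.7 percentage points lower from compound 2 to compound 3 (beyond the scatter) carries it well below compound 2, and compound 1 lies higher still. Going by the values given here, compound 1 and compound 2 differ from each other in two places at once, in the group on the carbonyl carbon and in the saturated chain, and their two numbers sit within the usual scatter of each other; no single-change step connects them.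

Compound 4 `CC(C)(C)c1ccc(C(=O)Nn2c(CCC3CCCC3)nc3c(-c4ccc(Cl)cc4)n[nH]c3c2=O)cc1` keeps the 4-(tert-butyl)phenyl group of compound 3 and changes only the chain. cyclopentylmethyl in place of cyclohexyl on a saturated chain carbon bound to an aromatic carbon Compound 4 thus has the same atoms as compound 3, joined differently, and its chain matches that of compound 1. Among the compounds with values here, no measured step isolates this chain change on its own. Within the data shown here, the only hint comes from compound 1 and compound 2, whose numbers lie close together even though they differ in the chain as well as in the aryl group. The expected step of a number 2.8 percentage points higher from compound 3 to compound 4 (within the scatter) is therefore small, with no direction beyond the scatter. Compound 4 is expected to give about 68% in this assay, most likely between 50% and 86%.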

Compound 4, a percentage reported as inhibition, at one concentration (the size of the read-out at that concentration, not a potency): 64.2%
Estimate against measurement, compound 4: 3.8 percentage points above; the range from low to high includes it.
By their numbers in this assay, from the lowest: compounds 4 and 3 (each within the scatter of the next); then compounds 2 and 1 (each within the scatter of the next).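

Going by these compounds alone, replacing cyclohexyl with cyclopentylmethyl, two groups with the same heavy-atom count, gives a number 1 percentage points lower from compound 3 to compound 4 (within the scatter) in this assay; this is the first direct reading of that chain change, and with the 4-(tert-butyl)phenyl group in place, the read-out does not separate the two chains. The other new step, with tert-butyl in place of hydrogen on an aromatic carbon, gives a number 25.4 percentage points lower from compound 1 to compound 4 (beyond the scatter), so the 4-(tert-butyl)phenyl group now goes with a clearly lower number on the cyclopentyl-bearing chain too, as it did on the cyclohexyl-bearing chain in a number 20.7 percentage points lower from compound 2 to compound 3 (beyond the scatter). Nothing available on these compounds gives a reason for either step.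

From the compounds shown here alone, it remains open whether the chain change would stay this quiet with a plain phenyl or a 3-methylphenyl group on the carbonyl carbon, since this single pair tests it only alongside the 4-(tert-butyl)phenyl group. The compounds shown also leave open how a methoxy group, an amine or a carboxylic acid in place of the tert-butyl group, or a longer straight chain such as n-hexyl in place of the ring-bearing chain, would read in this assay.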